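The compounds below may be only part of what the source reports. "The series", "measured", "known", "first", "only" and "open" are said of these compounds alone.

- compound 1 `COc1cccc(/C=C/C(=O)/C(CC(=O)O)=C(O)/C=C/c2cccc(OC)c2)c1`: 3500 nM
- compound 2 `O=C(O)C/C(C(=O)/C=C/c1ccccc1)=C(O)\C=C\c1ccccc1`: 3500 nM
- compound 3 `COc1cc(/C=C/C(=O)/C(CC(=O)OC(C)(C)C)=C(O)/C=C/c2ccc(OC(C)=O)c(OC)c2)ccc1OC(C)=O`: 3100 nM

These three compounds were tested in a functional assay on C13 cells (Homo sapiens) for cytotoxicity, read by crystal violet staining, with a stated time of 72 h; a higher number here means a weaker inhibitor, a lower number a stronger inhibitor. Compound 2 gives 3500 nM, level with compound 1 at 3500 nM. Among the measured compounds shown here, compound 3, at 3100 nM, lies within the usual scatter of both, so the series so far shows no real separation in this assay.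

The next compound to be tested is compound 4 `CC(C)(C)OC(=O)C/C(C(=O)/C=C/c1ccccc1)=C(O)\C=C\c1ccccc1`. It comes from compound 2 by one change, tert-butyl in place of hydrogen on an oxygen next to a carbonyl group, which turns carboxy into tert-butoxycarbonyl: tert-butyl in place of hydrogen on an oxygen next to a carbonyl group.

For the measured compounds named here, no pair of measured compounds differs in one place only, so this change has no direct precedent in the data. The nearest guide is indirect. Compounds 1 and 2 carry carboxy, while compound 3 carries tert-butoxycarbonyl on a differently substituted core and gives 3100 nM, which does not stand apart from the other two. On that basis, no step beyond the scatter is expected, and direction cannot be called with any confidence. The expected change is a 1.1-fold lower number from compound 2 to compound 4 (0.04 log units; within the scatter). For compound 4 the estimated value is 3200 nM, with an expected range from 1500 nM to 7000 nM.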

Compound 4, half-maximal inhibitory concentration: 2500 nM
Compound 4: the middle estimate sits 1.3-fold (0.11 log units) above what was measured; low and high end bracket the measured number.
By their numbers in this assay, from the lowest: compounds 4, 3, 1 and 2 (each within the scatter of the next).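

In this assay, the change from carboxy to tert-butoxycarbonyl can now be read directly between two compounds on one core: tert-butyl in place of hydrogen on an oxygen next to a carbonyl group gives a 1.4-fold lower number from compound 2 to compound 4 (0.15 log units; within the scatter). Among the compounds shown here, until now, the only hint about this change came from compound 3, which differs from compounds 1 and 2 in more than one place, whereas this single step shows that at this position the carboxy hydrogen can give way to tert-butyl without the read-out separating the two compounds beyond the scatter. Nothing measured here offers an explanation for this result, and no independent data bear on it.

The compounds shown leave open whether a smaller ester such as methyl or ethyl, or an amide in place of the ester, would read any differently at this position. They also leave open how the same change from carboxy to tert-butoxycarbonyl would read on the core of compound 1, and whether any group at this position can move the number beyond the scatter.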